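This account rests on a few compounds, and the source may have more. Where it says the series, first, only, none or still open, it means among the compounds named here.

Measured so far: compound 1 `O=C(CCCCCCc1ccccc1)c1ncc(-c2ncccn2)o1` with 5.3 nM and compound 2 `O=C(CCCCCCc1ccccc1)c1ncc(-c2nnn[nH]2)o1` with 63 nM.

Within the data shown here, in an assay (Rattus norvegicus) for inhibition of Fatty-acid amide hydrolase 1 (Homo sapiens) (a lower number here means a stronger inhibitor, a higher number a weaker inhibitor), compound 2 gives the higher of the two numbers, so it is the weaker inhibitor, with compound 1 as its only neighbour: a 12-fold higher number from compound 1 to compound 2 (1.08 log units; beyond the scatter).

Compound 3 `CN(C)C(=O)c1cnc(C(=O)CCCCCCc2ccccc2)o1` is not yet measured. It differs from compound 2 in one place: dimethylcarbamoyl in place of 1H-tetrazol-5-yl on an aromatic carbon.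

Among the measured compounds shown here, no measured step involves dimethylcarbamoyl, so only the step from compound 1 to compound 2 is available, and it shows that exchanging the group on this carbon can move the number by a large amount. For compound 3 the estimated result is 30 nM, within 8 nM to 120 nM, which would mean an expected step of a 2.1-fold lower number from compound 2 to compound 3 (0.32 log units; beyond the scatter).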

Compound 3, inhibition constant: 2 nM
Estimate against measurement, compound 3: 15-fold (1.18 log units) above; measured number outside the range, below it.
By their numbers in this assay, from the lowest: compound 3; then compound 1; then compound 2.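

A ring is not needed on this carbon next to the ring oxygen. In this assay, dimethylcarbamoyl, which has no ring, gives a 32-fold lower number from compound 2 to compound 3 (1.50 log units; beyond the scatter) in place of 1H-tetrazol-5-yl, and a 2.7-fold lower number from compound 1 to compound 3 (0.42 log units; beyond the scatter) in place of pyrimidin-2-yl, so a change here can strengthen inhibition as well as weaken it. Nothing available explains why these groups rank as they do.

Still open, from the compounds shown here alone, is whether both methyl groups of the amide matter, which an unsubstituted amide could show. A carboxylic acid or a methyl ester on this carbon would show whether the amide nitrogen matters.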